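Amide to Amine on a Shared Core: Cytotoxicity Outlook

This account rests on a few compounds, and the source may have more. Where it says the series, first, only, none or still open, it means among the compounds named here.

Compound 1 `Cc1ccc2nc(Cn3c(=O)n(C4CC4)c4ccncc43)c(CCCCO)n2c1`: > 100000 nM
Compound 2 `CCc1ccn2c(CCCCO)c(Cn3c(=O)n(C4CC4)c4ccncc43)nc2c1`: > 100000 nM
Compound 3 `O=C(NCCO)c1c(Cn2c(=O)n(C3CC3)c3ccncc32)nc2cc(Cl)ccn12`: > 100000 nM

Three compounds built on a shared core were tested in an ADME assay on HEp-2 cells (Homo sapiens) for cytotoxicity, read by CCK-8 assay, with a stated time of 6 days; a higher number here means that more compound is tolerated, a lower number that less compound is tolerated. Compound 1 gives > 100000 nM, which is a limit of the assay rather than a number. Compound 2 likewise gives > 100000 nM, again a limit. Compound 3 gives > 100000 nM, also a limit and not a measured value. Compound 3 therefore stands nowhere in particular on the numbers shown: all three results are limits, and nothing separates one compound from another within this group.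

The next compound, compound 4 `O=c1n(Cc2nc3cc(Cl)ccn3c2CNCCO)c2cnccc2n1C1CC1`, differs from compound 3 in one place: ((2-hydroxyethyl)amino)methyl in place of (2-hydroxyethyl)carbamoyl on an aromatic carbon. Among the compounds with values here, no step between measured compounds is available to show how such a change affects tolerance in this assay. Within the data shown here, since compound 3 sits at a limit, the only change that could be detected would be a drop in tolerated concentration into the measurable range.

Among the measured compounds shown here, the expectation for compound 4 is no movement beyond the scatter, so that it too is expected to give a limit, because every value so far sits at the limit of > 100000 nM in this assay, at which 3 of the 3 values shown sit. Compound 4 is thus estimated at 100000 nM, with a range from 50000 nM to 200000 nM, and the expected step of a number no higher from compound 3 to compound 4 (the limit leaves the size open) is essentially flat.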

Compound 4, half-maximal cytotoxic concentration: > 100000 nM
Compound 4: no number, only a limit; the forecaster's own chance of this, stated with the estimate: 85%; the middle value sits exactly at the limit.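

Compound 4 gives > 100000 nM, which is a limit of the assay and not a number. Compound 3 also stands at a limit, so no step can be read between compound 3 and compound 4. The compounds shown leave open how ((2-hydroxyethyl)amino)methyl and (2-hydroxyethyl)carbamoyl compare in tolerated concentration, and what change to the shared core would give a measurable value.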